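Same Side-Chain Swap Tried on a Rearranged Core

A few compounds are considered here, and "the series" means these few. Any claim that something is new, unique, unknown or untested is made for them only; others in the source may bear on it.

Measured in an assay on cells for agonist activity at vitamin D3 receptor (Homo sapiens), read by microscopy; on this read-out higher numbers stand for an effect only at larger amounts of compound and lower numbers for an effect already at smaller amounts:
compound 1 `CCn1c(C(=O)N[C@H](C(=O)O)C(C)C)ccc1C(CC)(CC)c1ccc(C#CC(O)(CC)CC)c(C)c1`: 17.7 nM
compound 2 `CCn1c(C(=O)NCCC(=O)O)ccc1C(CC)(CC)c1ccc(C#CC(O)(CC)CC)c(C)c1`: 293 nM
compound 3 `CCn1cc(C(CC)(CC)c2ccc(C#CC(O)(CC)CC)c(C)c2)cc1C(=O)NCCC(=O)O`: > 50 nM, which is a limit of the assay and not a number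

Between compound 2 and compound 1 the change is 1-carboxy-2-methylpropyl in place of 2-carboxyethyl on an amide-type nitrogen, and it made a 17-fold lower number from compound 2 to compound 1 (1.22 log units; beyond the scatter). Compound 3 has the same atoms as compound 2 joined differently; the difference between the two cores is not broken down here. Among the measured compounds shown here, because compound 3 sits at the limit of > 50 nM in this assay, at which 1 of the 3 values shown sits, no measured step from compound 2 to compound 3 can be given.

Compound 4 `CCn1cc(C(CC)(CC)c2ccc(C#CC(O)(CC)CC)c(C)c2)cc1C(=O)N[C@H](C(=O)O)C(C)C` arises from compound 3 by 1-carboxy-2-methylpropyl in place of 2-carboxyethyl on an amide-type nitrogen, the same change made on an amide-type nitrogen whose other neighbour is a carbonyl carbon. The expected step is an at least 1.2-fold lower number from compound 3 to compound 4 (0.09 log units; that floor lies within the scatter), beside the measured 17-fold lower number from compound 2 to compound 1 (1.22 log units; beyond the scatter), and it rests on compound 2 and compound 1 alone. With compound 3 known only as a limit, compound 4 is estimated at 40 nM, between 8 nM and 300 nM.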

Compound 4, half-maximal effective concentration: 12.7 nM
Compound 4: the middle estimate sits 3.1-fold (0.50 log units) above what was measured; the range from low to high includes it.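

On the rearranged core, 1-carboxy-2-methylpropyl in place of 2-carboxyethyl on the amide-type nitrogen again gave a lower number in this assay, with an at least 3.9-fold lower number from compound 3 to compound 4 (0.59 log units; beyond the scatter), so the direction of the step carried over from one core to the other: the same change on two cores in this assay, a 17-fold lower number (1.22 log units; beyond the scatter) from compound 2 to compound 1 and an at least 3.9-fold lower number (0.59 log units; beyond the scatter) from compound 3 to compound 4; the limit leaves it open whether they differ

Compound 3 stands at > 50 nM, which is a limit of the assay and not a number. On these data alone, the size of the step on this core therefore stays unknown, and two cores give no rule for the whole series.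

The compounds shown leave open how carboxymethyl or 1-carboxyethyl on the same nitrogen would read in this assay on either core. They also leave open what an amine in place of the carboxylic acid at the end of the chain would do.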